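Nitroimidazooxazine series: aryl swap and Vero cell tolerance

The source may hold more compounds than are shown below. What is called first, only, known or untested is meant among the compounds shown, and "the series" means these compounds.

Compound 1 `C[C@]1(CN2CCc3nc(-c4ccc(OC(F)(F)F)cc4)ccc3C2)Cn2cc([N+](=O)[O-])nc2O1` carries a 4-(trifluoromethoxy)phenyl on the shared core; in an ADME assay on Vero cells (Chlorocebus sabaeus) for cytotoxicity, read by MTT assay, with a stated time of 72 h (a higher number here means that more compound is tolerated, a lower number that less compound is tolerated), compound 1 gives "not determined" (no result reported), so no number places it on the scale. Compound 2 `C[C@]1(CN2CCc3nc(-c4ccccc4)ncc3C2)Cn2cc([N+](=O)[O-])nc2O1` likewise gives "not determined" (no result reported) in this assay. Compound 3 `C[C@]1(CN2CCc3nc(-c4ccc(F)cc4)oc3C2)Cn2cc([N+](=O)[O-])nc2O1` in this assay gives > 32 ug/mL, which is a limit of the assay and not a number. Going by the values given here, the only reading in the set is thus (the limit of > 32 ug/mL in this assay, at which 1 of the 3 values shown sits). Compound 4 `C[C@]1(CN2CCc3nc(-c4ccc(F)cc4F)ccc3C2)Cn2cc([N+](=O)[O-])nc2O1` differs from compound 1 by 2,4-difluorophenyl in place of 4-(trifluoromethoxy)phenyl on an aromatic carbon. Among the compounds with values here, no measured step exists between compounds of this set, so no size or direction of shift beyond the scatter can be drawn from data; the single reading available points to tolerance reaching the limit. Compound 4 is expected in this assay at 40 ug/mL, within 16 ug/mL to 100 ug/mL.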

Compound 4, half-maximal cytotoxic concentration: 12.5 ug/mL
For compound 4 the middle estimate is 3.2-fold (0.51 log units) above the measured one; measured number outside the range, below it.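

In this assay, going by these compounds alone, compound 4 gives 12.5 ug/mL, but no step from compound 1 to compound 4 can be read. Going by these compounds, whether 2,4-difluorophenyl in place of 4-(trifluoromethoxy)phenyl shifts tolerance on the shared core remains open.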